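The compounds below may be only part of what the source reports. "The series", "measured", "known", "first", "only" and "open" are said of these compounds alone.

Measured so far in a functional assay on the whole organism for agonist activity, with Mus musculus as the target; on this read-out lower numbers stand for an effect already at smaller amounts and higher numbers for an effect only at larger amounts of compound:
- Compound 1 `Cn1ccn(CC#CCN2CCCC2)c1=O`: 6.6 mg/kg
- Compound 2 `Cn1ccn(CC#CCn2ccnc2)c1=O`: 3.7 mg/kg

Among the compounds with values here, with only two numbers available, compound 2 cannot be separated from compound 1, as the step between them is a 1.8-fold lower number from compound 1 to compound 2 (0.25 log units; within the scatter). Compound 3 `CN(C)CC#CCn1ccn(C)c1=O` keeps the shared core and changes a single group: dimethylamino in place of 1H-imidazol-1-yl on a saturated chain carbon bound to a triple-bonded carbon. Within the data shown here, the only measured step that bears on this change is the one above, which exchanged a different pair of groups at the same place, on a saturated chain carbon bound to a triple-bonded carbon. That step stayed within the scatter. Among the measured compounds shown here, it is thin evidence, and no compound carrying dimethylamino has been measured yet. In this assay, no shift beyond the scatter is therefore expected, and the estimated step is a 1.5-fold higher number from compound 2 to compound 3 (0.17 log units; within the scatter). The expected value for compound 3 is 5.5 mg/kg, with an estimated range from 2.2 mg/kg to 14 mg/kg.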

Compound 3, dose for half-maximal effect: 8 mg/kg
Compound 3: middle estimate off by 1.5-fold (0.16 log units), on the low side; the range from low to high includes it.
By their numbers in this assay, from the lowest: compounds 2, 1 and 3 (each within the scatter of the next, the first and the last beyond it).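

In this assay, this position now shows its first step beyond the scatter, though only a modest one: dimethylamino in place of 1H-imidazol-1-yl gives a 2.2-fold higher number from compound 2 to compound 3 (0.33 log units; beyond the scatter). Dimethylamino in place of pyrrolidin-1-yl, by contrast, gives a 1.2-fold higher number from compound 1 to compound 3 (0.08 log units; within the scatter), so the open-chain group and the saturated ring cannot be told apart here, and 1H-imidazol-1-yl differs measurably only from dimethylamino, not from pyrrolidin-1-yl. Nothing available here explains why the numbers fall as they do.

Still open, from the compounds shown here alone, is how other amines at this place would compare, such as diethylamino or piperidin-1-yl, and whether a different aromatic ring, such as 1H-pyrazol-1-yl, would behave like 1H-imidazol-1-yl. Also open, going by these compounds, is whether a longer chain carrying these same groups would keep the small differences seen so far.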